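From a Dimethylthiazole to a Methyltriazole on the Shared Core

A few compounds are considered here, and "the series" means these few. Any claim that something is new, unique, unknown or untested is made for them only; others in the source may bear on it.

Compound 1 `CCc1c(OC)nc2nc(-c3nnc(C)o3)cn2c1C` gives 2 mg/kg in a functional assay on the whole organism with Rattus norvegicus as the target; a lower number here means that less compound is needed, a higher number that more compound is needed for the effect.
Compound 2 `CCc1c(OC)nc2nc(-c3nc(C)cs3)cn2c1C` gives > 50 mg/kg, which is a limit of the assay and not a number.
Compound 3 `CCc1c(OC)nc2nc(-c3nc(C)c(C)s3)cn2c1C` gives > 50 mg/kg, likewise a limit of the assay.

Compound 3 therefore sits at the limit of > 50 mg/kg in this assay, at which 2 of the 3 values shown sit, without a readable number of its own. The change to compound 4 `CCc1c(OC)nc2nc(-c3n[nH]c(C)n3)cn2c1C` is 5-methyl-1H-1,2,4-triazol-3-yl in place of 4,5-dimethyl-1,3-thiazol-2-yl on an aromatic carbon. The measured steps that bear on it are an at least 25-fold higher number from compound 1 to compound 3 (1.39 log units; beyond the scatter) and an at least 25-fold higher number from compound 1 to compound 2 (1.39 log units; beyond the scatter): in both, a five-membered ring with three hetero atoms gave way to a ring with two hetero atoms and a sulfur, and the dose rose sharply. The step that the two limits leave unreadable from compound 2 to compound 3 cannot be read. Compound 4 brings back a ring with three hetero atoms, close to the ring of compound 1, so the step is expected to run the other way, as an at least 10-fold lower number from compound 3 to compound 4 (1.00 log units; beyond the scatter). Compound 4 is thus estimated at 5 mg/kg, expected to fall between 1.5 mg/kg and 40 mg/kg.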

Compound 4, minimum effective dose: > 50 mg/kg
Compound 4: a limit, no number; the forecaster's own chance of this, stated with the estimate: 30%; middle value at least 10-fold (1.00 log units) from the limit.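

In this assay compound 4 gives > 50 mg/kg, which is a limit of the assay and not a number. Bringing back a five-membered aromatic ring with 3 hetero atoms is therefore not enough on its own, since 5-methyl-1H-1,2,4-triazol-3-yl in place of 5-methyl-1,3,4-oxadiazol-2-yl still gives an at least 25-fold higher number from compound 1 to compound 4 (1.39 log units; beyond the scatter); the steps among compounds 2, 3 and 4 cannot be read. Of the groups shown at this position, only the 5-methyl-1,3,4-oxadiazol-2-yl of compound 1 gives a readable dose, and the rest share one ceiling: the limit of > 50 mg/kg in this assay, at which 3 of the 4 values shown sit.

On these data alone, how far compounds 2, 3 and 4 differ beyond that limit stays unknown. Also open, as far as these compounds go, is whether a 1,2,4-oxadiazole ring, or an ethyl group in place of the methyl on the 1,3,4-oxadiazole, would keep the low dose of compound 1.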